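A few compounds are considered here, and "the series" means these few. Any claim that something is new, unique, unknown or untested is made for them only; others in the source may bear on it.

Compounds measured so far:
compound 1 `Fc1ccc(C2CC(c3ccc(Cl)s3)=NN2c2nc(-c3ccc(C(F)(F)F)cc3)cs2)cc1`
compound 2 `N#Cc1ccc(-c2csc(N3N=C(c4ccc(Cl)s4)CC3c3ccc(F)cc3)n2)cc1`
compound 3 `Fc1ccc(C2CC(c3ccc(Cl)s3)=NN2c2nc(-c3ccccc3)cs2)cc1`

In a functional assay on A549 cells (Homo sapiens) for antiproliferative activity, read by XTT assay, with a stated time of 24 h (a higher number here means a weaker inhibitor, a lower number a stronger inhibitor), compound 1 gives > 500 ug/mL, which is a limit of the assay and not a number. Compound 2 likewise gives only a limit, > 500 ug/mL. Compound 3 also gives only a limit, > 500 ug/mL. All three values thus rest at the limit of > 500 ug/mL in this assay, at which 3 of the 3 values shown sit, so compound 3 stands nowhere readable against the other two. The steps a step that the two limits leave unreadable from compound 1 to compound 2, a step that the two limits leave unreadable from compound 1 to compound 3 and a step that the two limits leave unreadable from compound 2 to compound 3 are all unreadable: neither cyano, trifluoromethyl nor hydrogen at that aromatic carbon brought the read-out off the limit.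

Compound 4 `O=[N+]([O-])c1ccc(-c2csc(N3N=C(c4ccc(Cl)s4)CC3c3ccc(F)cc3)n2)cc1` carries the change (nitro in place of hydrogen on an aromatic carbon). Within the data shown here, no measured step bears on it with a readable size; the only related comparisons, all at the same aromatic carbon, left three compounds at the limit. No step beyond the scatter is expected in this assay from the change, so the estimated step is a step that the limit leaves unreadable from compound 3 to compound 4. Compound 4 is therefore expected to give 600 ug/mL, within 200 ug/mL to 2000 ug/mL, and most likely to be reported only as a limit.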

Compound 4, half-maximal inhibitory concentration: > 500 ug/mL
Compound 4: no number, only a limit (the forecaster's own chance of this, stated with the estimate: 80%); the middle value does not contradict the limit.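

In this assay compound 4 gives > 500 ug/mL, a limit of the assay and not a number. The steps joining compound 4 to compound 1, compound 2 and compound 3 therefore cannot be read: the limit of > 500 ug/mL in this assay, at which 4 of the 4 values shown sit. The compounds shown leave open whether any change to the shared core brings the read-out off this limit.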